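A Third Aryl Group on the Ring Nitrogen of Compound 1

This account rests on a few compounds, and the source may have more. Where it says the series, first, only, none or still open, it means among the compounds named here.

Compound 1 `CC(C)N1CCN(Cc2csc(N)c2C(=O)c2ccc(Cl)cc2)CC1` is one of three compounds sharing a core and differing only in the group on an amine nitrogen in a ring. In an assay on CHO cells for displacement of a labelled ligand from adenosine receptor A1 (Homo sapiens), read by scintillation counting, with a stated time of 120 min, tested at 10 uM (on this read-out lower numbers stand for less inhibition and higher numbers for more inhibition at the one concentration tested (going by the name of the read-out)), compound 1 gives 0%, level with compound 3 `Nc1scc(CN2CCN(c3ccc(OC(F)(F)F)cc3)CC2)c1C(=O)c1ccc(Cl)cc1`, which gives 0%; together they are the lowest of the three numbers. Compound 2 `Nc1scc(CN2CCN(c3cccc(Cl)c3Cl)CC2)c1C(=O)c1ccc(Cl)cc1` gives 2%. Every step among them stays inside the scatter: a number 2 percentage points higher from compound 1 to compound 2 (within the scatter), no change at the digits printed from compound 1 to compound 3 (within the scatter) and a number 2 percentage points lower from compound 2 to compound 3 (within the scatter).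

Compound 4 `Nc1scc(CN2CCN(c3cccc(F)c3)CC2)c1C(=O)c1ccc(Cl)cc1` differs from compound 1 in one place: 3-fluorophenyl in place of isopropyl on an amine nitrogen in a ring. The two measured steps in which an aromatic group replaces the isopropyl on that ring nitrogen bear directly on this change, and neither of them moved the number beyond the scatter. No step beyond the scatter is therefore expected in this assay, so that the expected step is a number 1 percentage points higher from compound 1 to compound 4 (within the scatter). Compound 4 is estimated at 1%, with a range from -6% to 9%.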

Compound 4, a percentage reported as inhibition, at one concentration (the size of the read-out at that concentration, not a potency): 1%
Beside the measured number, compound 4's estimate shows no gap at the digits printed; low and high end bracket the measured number.
By their numbers in this assay, from the lowest: compounds 1, 3, 4 and 2 (each within the scatter of the next).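

In this assay, a single fluorine on a phenyl group on the ring nitrogen gives the same picture as the two more heavily substituted aryl groups, with a number 1 percentage points higher from compound 1 to compound 4 (within the scatter). The new group is also not separated from either of those aryl groups, with a number 1 percentage points higher from compound 3 to compound 4 (within the scatter) and a number 1 percentage points lower from compound 2 to compound 4 (within the scatter), so isopropyl and all three aryl groups at this position now give numbers that cannot be told apart. No measurement at hand explains this lack of separation.

The compounds shown leave open whether a different kind of group on this ring nitrogen, such as a carboxylic acid or a longer chain ending in an amine, would give a number beyond the scatter. They also leave open whether replacing the 4-chlorophenyl group on the carbonyl would do so.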